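Aryl swap on the ring nitrogen of compound 3

The source may report more compounds than this note shows. Statements on the series, on what has been measured and on what is new or still open speak of the compounds shown alone.

Measured compounds:
Compound 1 `Cc1ccccc1-n1nncc1CN1C(=O)C2(C(C#N)=C(N)Oc3c2c2nc4ccccc4nc2c2ccccc32)c2ccccc21` gives > 50000 nM in a functional assay on A549 cells (Homo sapiens) for antiproliferative activity, read by MTT assay, with a stated time of 48 h; on this read-out higher numbers stand for weaker inhibition and lower numbers for stronger inhibition; this value is a limit of the assay, not a number.
Compound 2 `CC(=O)Nc1ccc(-n2nncc2CN2C(=O)C3(C(C#N)=C(N)Oc4c3c3nc5ccccc5nc3c3ccccc43)c3ccccc32)cc1` gives > 50000 nM in this assay; this too is a limit.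
Compound 3 `CCOc1ccc(-n2nncc2CN2C(=O)C3(C(C#N)=C(N)Oc4c(N)cc5nc6ccccc6nc5c43)c3ccccc32)cc1` gives > 50000 nM in this assay; again only a limit.

Compound 3 therefore stands at the edge of what this assay can report, and every other value shown sits at the same place: the limit of > 50000 nM in this assay, at which 3 of the 3 values shown sit. For the measured compounds named here, the one step between measured compounds, a step that the two limits leave unreadable from compound 1 to compound 2, cannot be read in size or direction, since both ends are limits.

Compound 4 `Cc1cc(C)c(-n2nncc2CN2C(=O)C3(C(C#N)=C(N)Oc4c(N)cc5nc6ccccc6nc5c43)c3ccccc32)c(C)c1` is the next compound. Its difference from compound 3 is 2,4,6-trimethylphenyl in place of 4-ethoxyphenyl on an aromatic nitrogen. Going by the values given here, no measured step bears on this change, and the only step available is unreadable. With three limits and nothing that points elsewhere, compound 4 is expected to remain at the limit as well, so the step of a number no higher from compound 3 to compound 4 (the limit leaves the size open) is estimated to be none beyond the scatter. The estimate for compound 4 is 50000 nM, with a range from 20000 nM to 200000 nM.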

Compound 4, half-maximal inhibitory concentration: 12700 nM
The estimate for compound 4 lay 3.9-fold (0.60 log units) above the measured number; measured number outside the range, below it.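

Placing 2,4,6-trimethylphenyl where compound 3 carries 4-ethoxyphenyl gives an at least 3.9-fold lower number from compound 3 to compound 4 (0.59 log units; beyond the scatter) in this assay. For the compounds shown here, this is the first sign that the aryl group on this ring nitrogen can move the read-out at all, since the earlier step could not be read and the earlier values stayed at one limit: the limit of > 50000 nM in this assay, at which 3 of the 4 values shown sit. Compound 4 is the first compound here with a real number, although the full size of the step stays open, as the value for compound 3 is only a limit.

The change removes the ethoxy group and adds three methyl groups at once, so the compounds shown cannot tell which of these matters. On these data alone, whether a plain phenyl or a benzyl group on this nitrogen would also give a number below the limit remains open.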